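A Second Nitro Group on an Inactive Series

This account rests on a few compounds, and the source may have more. Where it says the series, first, only, none or still open, it means among the compounds named here.

Measured so far in a functional assay on HeLa cells (Homo sapiens) for inhibition, read by CCK-8 assay, with a stated time of 48 h; on this read-out higher numbers stand for weaker inhibition and lower numbers for stronger inhibition:
compound 1 `COc1ccc(NC(=O)NCCNS(=O)(=O)c2ccc(-c3ccccc3OCc3ccccc3)s2)cc1` gives > 50000 nM as a limit
compound 2 `O=C(NCCNS(=O)(=O)c1ccc(-c2ccccc2Oc2ccc([N+](=O)[O-])c([N+](=O)[O-])c2)s1)Nc1cc(Cl)cc(Cl)c1` gives > 20000 nM as a limit
compound 3 `COc1ccc(NC(=O)NCCNS(=O)(=O)c2ccc(-c3ccccc3Oc3ccc([N+](=O)[O-])cc3)s2)cc1` gives > 20000 nM as a limit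

Compound 3 has no number and stands only at the limit > 20000 nM in this assay, as do the other two compounds at their own limits. Compound 4 `COc1ccc(NC(=O)NCCNS(=O)(=O)c2ccc(-c3ccccc3Oc3ccc([N+](=O)[O-])c([N+](=O)[O-])c3)s2)cc1` differs from it by nitro in place of hydrogen on an aromatic carbon, which is nitro in place of hydrogen on an aromatic carbon. For the measured compounds named here, the only measured step is a step that the two limits leave unreadable from compound 1 to compound 3 and it gives no size to build on. Compound 2 also carries 3,4-dinitrophenyl but differs elsewhere, and it remains at the limit > 20000 nM in this series. No change beyond the scatter is therefore expected, and the expected step is a step that the limit leaves unreadable from compound 3 to compound 4 in no clear direction. Compound 4 is estimated at 25000 nM with an expected range from 10000 nM to 60000 nM in this assay overall.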

Compound 4, half-maximal inhibitory concentration: > 20000 nM
Compound 4: a limit, no number; the forecaster's own chance of this, stated with the estimate: 75%; the middle value lies beyond the limit too.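

In this assay compound 4 gives > 20000 nM, a limit and not a number. For the compounds shown here, no step to compound 4 from compound 1, compound 2 or compound 3 can be read. The compounds shown leave open whether any of these changes alters inhibition at all.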